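The compounds below may be only part of what the source reports. "The series", "measured", "known", "first", "only" and "open" are said of these compounds alone.

Measured so far, with each value a limit of the assay:
- compound 1 `O=c1nc(N2CCN(NC3CCCCC3)CC2)sc2c([N+](=O)[O-])cc(C(F)(F)F)cc12`: in an ADME assay on Vero cells (Chlorocebus sabaeus) for cytotoxicity, read by MTT assay, with a stated time of 72 h (on this read-out lower numbers stand for higher toxicity in this test and higher numbers for lower toxicity in this test), compound 1 gives > 64 ug/mL, a limit.
- compound 2 `O=c1nc(N2CCN(NCCC3CCCCC3)CC2)sc2c([N+](=O)[O-])cc(C(F)(F)F)cc12`: in this assay compound 2 gives > 64 ug/mL, a limit.
- compound 3 `CON=C1CCC(N(C)N2CCN(c3nc(=O)c4cc(C(F)(F)F)cc([N+](=O)[O-])c4s3)CC2)CC1`: in this assay compound 3 gives > 64 ug/mL, a limit.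

Compound 2 therefore stands only at a limit, as do the others (the limit of > 64 ug/mL in this assay, at which 3 of the 3 values shown sit). The measured steps a step that the two limits leave unreadable from compound 1 to compound 2, a step that the two limits leave unreadable from compound 1 to compound 3 and a step that the two limits leave unreadable from compound 2 to compound 3 give no readable size, so the series offers no scale for any change on this side of the core of compound 2.

Compound 4 `O=c1nc(N2CCN(NCc3ccc(OC(F)(F)F)cc3)CC2)sc2c([N+](=O)[O-])cc(C(F)(F)F)cc12` carries 4-(trifluoromethoxy)phenyl in place of cyclohexylmethyl on a saturated chain carbon bound to an amine nitrogen. The measured steps bear on it only in that no change tried so far has brought a value inside the measured window. The expected step is a number no higher from compound 2 to compound 4 (the limit leaves the size open), that is, none beyond the scatter. Compound 4 is estimated at 64 ug/mL, range 32 ug/mL to 128 ug/mL, most likely reported again as a limit.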

Compound 4, half-maximal cytotoxic concentration: > 64 ug/mL
Compound 4 was reported as a limit (the forecaster's own chance of this, stated with the estimate: 75%); the middle value lies on the limit itself.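

Neither the step from compound 2 to compound 4 nor the step from compound 1 to compound 4 can be read, since every value shown is a limit: the limit of > 64 ug/mL in this assay, at which 4 of the 4 values shown sit. The compounds shown leave open which change on this side of the core, if any, would bring a value inside the measured window of this assay.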